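From piperazin-1-yl to 3,5-dimethylpiperazin-1-yl on a carbonyl carbon

The source may hold more compounds than are shown below. What is called first, only, known or untested is meant among the compounds shown, and "the series" means these compounds.

- Compound 1 `COc1cc(O)c2c(=O)cc(-c3ccc(NS(=O)(=O)C4CC4)cc3)oc2c1OC(C)C` gives 8800 nM
- Compound 2 `COc1cc(O)c2c(=O)cc(-c3ccc(NC(=O)NC4CC4)cc3)oc2c1OC(C)C` gives 13800 nM
- Compound 3 `COc1cc(O)c2c(=O)cc(-c3ccc(NC(=O)N4CCNCC4)cc3)oc2c1OC(C)C` gives 9500 nM

These values come from a functional assay on LNCaP cells (Homo sapiens) for antiproliferative activity, read by MTT assay, with a stated time of 3 days (on this read-out higher numbers stand for weaker inhibition and lower numbers for stronger inhibition), and lie within the usual scatter of one another. Compound 3, at 9500 nM, has no gap beyond the scatter to either of the other two.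

Compound 4 `COc1cc(O)c2c(=O)cc(-c3ccc(NC(=O)N4CC(C)NC(C)C4)cc3)oc2c1OC(C)C` keeps the shared core and changes one group: 3,5-dimethylpiperazin-1-yl in place of piperazin-1-yl on a carbonyl carbon. In words, 3,5-dimethylpiperazin-1-yl stands in place of piperazin-1-yl on a carbonyl carbon.

Among the compounds with values here, no measured step tests this exact swap. The closest is a 1.5-fold lower number from compound 2 to compound 3 (0.16 log units; within the scatter), with piperazin-1-yl in place of cyclopropylamino on a carbonyl carbon. The steps of a 1.6-fold higher number from compound 1 to compound 2 (0.20 log units; within the scatter) and a 1.1-fold higher number from compound 1 to compound 3 (0.03 log units; within the scatter) also stay small. Going by these steps, no change beyond the scatter is expected in this assay.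

For compound 4 the expected change is no change at the digits printed from compound 3 to compound 4 (within the scatter).

Compound 4 is estimated at 9500 nM, with an expected range of 4700 nM to 19000 nM.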

Compound 4, half-maximal inhibitory concentration: 2800 nM
The estimate for compound 4 lay 3.4-fold (0.53 log units) above the measured number, outside the stated range (below it).
By their numbers in this assay, from the lowest: compound 4; then compounds 1, 3 and 2 (each within the scatter of the next).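

In this assay, within the data shown here, replacing piperazin-1-yl with 3,5-dimethylpiperazin-1-yl on the carbonyl carbon gives a 3.4-fold lower number from compound 3 to compound 4 (0.53 log units; beyond the scatter), whereas every step among the earlier compounds stayed within the scatter. The new group also separates compound 4 from the other two compounds, with a 4.9-fold lower number from compound 2 to compound 4 (0.69 log units; beyond the scatter) and a 3.1-fold lower number from compound 1 to compound 4 (0.50 log units; beyond the scatter), making compound 4 the most potent of the four in this assay and showing that the group on this carbonyl carbon can change the read-out. No measurement shown here explains why this change lowers the number.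

The compounds shown leave open whether 3-methylpiperazin-1-yl, with a single methyl on the ring, or a morpholine ring on the same carbonyl carbon would also lower the number. They also leave open how a larger group, such as 3,5-diethylpiperazin-1-yl, would behave at this place.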